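Rearranging the carbonyl substituent of compound 1

This account rests on a few compounds, and the source may have more. Where it says the series, first, only, none or still open, it means among the compounds named here.

In a physicochemical assay for lipophilicity (on this read-out higher numbers stand for higher lipophilicity and lower numbers for lower lipophilicity), compound 1 `CNCC(=O)Nc1ccc(-c2nc(CS(C)(=O)=O)cc([C@@]34CCOC[C@@H]3C4)n2)cc1` gives 3.1, the lowest of the three numbers measured. Compound 2 `CS(=O)(=O)Cc1cc([C@]23CCOC[C@H]2C3)nc(-c2cccc(O)c2)n1` gives 3.7, and compound 3 `CNCC(=O)Nc1ccc(-c2nc(C(C)(C)S(C)(=O)=O)cc([C@@]34CCOC[C@@H]3C4)n2)cc1` gives 4.3. Compound 4 `CCNC(=O)Nc1ccc(-c2nc(CS(C)(=O)=O)cc([C@@]34CCOC[C@@H]3C4)n2)cc1` holds the same atoms as compound 1, joined differently, with ethylamino in place of (methylamino)methyl on a carbonyl carbon. Going by the values given here, no measured step touches this carbonyl. Among the compounds with values here, the one measured step from compound 1, a number 1.20 log units higher from compound 1 to compound 3 (beyond the scatter), lies at another place and offers only a loose guide to the size of a change. A rise smaller than that step is therefore expected in this assay, and the expected step is a number 0.40 log units higher from compound 1 to compound 4 (beyond the scatter). For compound 4 the estimate is 3.5, with an expected range from 3 to 4.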

Compound 4, partition coefficient: 3.6
Estimate against measurement, compound 4: 0.10 log units below; measured number inside the range.
By their numbers in this assay, from the lowest: compound 1; then compounds 4 and 2 (each within the scatter of the next); then compound 3.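

In this assay, going by these compounds alone, the swap of (methylamino)methyl for ethylamino on a carbonyl carbon gives a number 0.50 log units higher from compound 1 to compound 4 (beyond the scatter), the first measured change at this carbonyl. It shows that the same atoms, joined differently, are enough to shift the number beyond the scatter. Nothing at hand explains the rise.

On these data alone, whether a longer chain such as propylamino, or a dimethylamino group, on this carbonyl carbon would shift the number further remains open. So does whether the step would hold alongside the 1-methyl-1-(methylsulfonyl)ethyl group of compound 3.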